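The source may report more compounds than this note shows. Statements on the series, on what has been measured and on what is new or still open speak of the compounds shown alone.

Compound 2 `COc1ccc(Cn2nnc(-c3ccccc3)c2C(=O)N[C@@H](C)c2ccc(C(=O)O)cc2)cc1OC` gives the lower of the two numbers recorded in a functional assay on CHO cells for antagonist activity at prostaglandin E2 receptor EP4 subtype (Homo sapiens), read by calcium flux, with a stated time of 15 min (on this read-out higher numbers stand for weaker inhibition and lower numbers for stronger inhibition), namely 119 nM. Among the compounds with values here, its nearest neighbour is compound 1 `C[C@H](NC(=O)c1c(-c2ccccc2)nnn1Cc1ccc(F)cc1)c1ccc(C(=O)O)cc1`, which in this assay gives 330 nM; the only change between them, 3,4-dimethoxyphenyl in place of 4-fluorophenyl on a saturated chain carbon bound to an aromatic nitrogen, produced a 2.8-fold lower number from compound 1 to compound 2 (0.44 log units; beyond the scatter).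

Compound 3 `C[C@H](NC(=O)c1c(-c2ccccc2)nnn1CCOc1ccc(C(F)(F)F)cc1)c1ccc(C(=O)O)cc1` differs from compound 2 at the same place, but by a change of a different kind: (4-(trifluoromethyl)phenoxy)methyl in place of 3,4-dimethoxyphenyl on a saturated chain carbon bound to an aromatic nitrogen. Within the data shown here, no measured step covers the entry of a (4-(trifluoromethyl)phenoxy)methyl group, so the step from compound 1 to compound 2 bears on it only in showing that this position tolerates exchange of the aromatic group with a modest shift in this assay. Among the measured compounds shown here, with no closer precedent, the expectation for compound 3 is a number near those already seen, leaning slightly upward, and the step from compound 2 is estimated as a 2.1-fold higher number from compound 2 to compound 3 (0.32 log units; beyond the scatter). Compound 3 is therefore expected to give about 250 nM in this assay, within a range from 60 nM to 1000 nM.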

Compound 3, half-maximal inhibitory concentration: 49.1 nM
For compound 3 the middle estimate is 5.1-fold (0.71 log units) above the measured one; the measured number lies below the stated range.
By their numbers in this assay, from the lowest: compound 3; then compound 2; then compound 1.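

In this assay, the (4-(trifluoromethyl)phenoxy)methyl group gives a 2.4-fold lower number from compound 2 to compound 3 (0.38 log units; beyond the scatter) and also a 6.7-fold lower number from compound 1 to compound 3 (0.83 log units; beyond the scatter), which places compound 3 lowest of the three. Within the data shown here, the earlier compounds showed only one substituted phenyl group exchanged for another on a saturated chain carbon bound to an aromatic nitrogen, whereas this result shows that the place also accepts a group with an ether oxygen in it and that the exchange can lower the number further than the 3,4-dimethoxyphenyl group did. Nothing measured here accounts for the lower number, so the result stands as an observation only.

The compounds shown change the ether oxygen and the trifluoromethyl group together, so they leave open which of the two goes with the lower number, a question that a plain phenoxymethyl group or a benzyl group carrying a trifluoromethyl would address. They also leave open how a longer chain ending in the same phenoxy group, or an amine in place of the ether oxygen, would read on this assay.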